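Adding a methyl beside the ring nitrogen: compound 2 to compound 4

This account rests on a few compounds, and the source may have more. Where it says the series, first, only, none or still open, it means among the compounds named here.

Measured so far in an assay on CHO cells for displacement of a labelled ligand from Substance-P receptor (Homo sapiens), with a stated time of 90 min; on this read-out higher numbers stand for weaker inhibition and lower numbers for stronger inhibition:
- compound 1 `Cc1nc2ccccc2c(-c2ccccc2)c1C(=O)N(C)Cc1cc(C(F)(F)F)cc(C(F)(F)F)c1`: 19 nM
- compound 2 `Cc1nccc(-c2ccccc2)c1C(=O)N(C)Cc1cc(C(F)(F)F)cc(C(F)(F)F)c1`: 98 nM
- compound 3 `Cc1nc(N2CCN(C)CC2)cc(-c2ccccc2)c1C(=O)NCc1cc(C(F)(F)F)cc(C(F)(F)F)c1`: 53 nM

The three compounds share the same amide and the same bis(trifluoromethyl)benzyl arm; they differ in the aromatic part that carries the phenyl group. Among the three numbers, compound 2 has the highest. Its nearest neighbour is compound 3, whose number lies within the usual scatter, so the two cannot be told apart. Compound 1 lies beyond the scatter, with a clearly lower number than compound 2.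

Compound 4 `Cc1cc(-c2ccccc2)c(C(=O)N(C)Cc2cc(C(F)(F)F)cc(C(F)(F)F)c2)c(C)n1` is not yet measured. It differs from compound 2 in one place: methyl in place of hydrogen on an aromatic carbon. Among the compounds with values here, no measured pair shows this exact change, so the expectation rests on what the three numbers suggest. Both compound 1 and compound 3 carry something at or around that part of the core and give lower numbers than compound 2, although only compound 1 does so beyond the scatter.

For compound 4 a modest step toward a lower number is expected, a 2.2-fold lower number from compound 2 to compound 4 (0.34 log units; beyond the scatter), and the estimate is 45 nM, with a range from 12 nM to 170 nM.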

Compound 4, half-maximal inhibitory concentration: 41 nM
The estimate for compound 4 lay 1.1-fold (0.04 log units) above the measured number; the range from low to high includes it.
By their numbers in this assay, from the lowest: compound 1; then compounds 4, 3 and 2 (each within the scatter of the next, the first and the last beyond it).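

Within the data shown here, compound 2 and compound 4 are the first pair here that differ in one place only, so this change can be read on its own: in this assay, methyl in place of hydrogen on an aromatic carbon next to the ring nitrogen gives a 2.4-fold lower number from compound 2 to compound 4 (0.38 log units; beyond the scatter). The step is modest but beyond the scatter, which shows that this position accepts a methyl and that even one added carbon can lower the number. The earlier compounds shown here could only hint at this, since compound 1 and compound 3 differ from compound 2 in more than one place. Nothing measured here explains why the methyl has this effect.

From the compounds shown here alone, it remains open whether the number would keep falling with an ethyl group at this position, or how it would respond to a chlorine atom, a methoxy group or an amine there. It is also unknown whether the same methyl would give a similar step on a compound with the amide hydrogen, such as compound 3, where the amide of compound 4 carries a methyl.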